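A few compounds are considered here, and "the series" means these few. Any claim that something is new, unique, unknown or untested is made for them only; others in the source may bear on it.

Compound 1 `CN(C)CCCOc1ccc(CN2CC[C@H](NC(=O)c3cc(Cl)cc(Cl)c3)C2)cc1` gives 2000 nM in an assay on HEK293 cells for binding affinity to Urotensin-2 receptor (Homo sapiens), read by radioligand binding; on this read-out lower numbers stand for stronger inhibition and higher numbers for weaker inhibition.
Compound 2 `COc1ccc(C(=O)N[C@H]2CCN(Cc3ccc(OCCCN(C)C)cc3)C2)cc1OC` gives only a limit in this assay, < 10000 nM.
Compound 3 `Cc1ccc(C(=O)N[C@H]2CCN(Cc3ccc(OCCCN(C)C)cc3)C2)cc1C` gives only a limit in this assay, < 10000 nM.

Compound 2 stands at the limit of this assay, and no number for it is known. The account follows the step from compound 2 to compound 4 `CN(C)CCCOc1ccc(CN2CC[C@H](NC(=O)c3ccc(C#N)cc3)C2)cc1`, in which (4-cyanophenyl in place of 3,4-dimethoxyphenyl on a carbonyl carbon). For the measured compounds named here, three measured steps touch this position on the carbonyl carbon. The step that the limit leaves unreadable from compound 1 to compound 2 and the step that the limit leaves unreadable from compound 1 to compound 3 each run from a number into a limit, and the step that the two limits leave unreadable from compound 2 to compound 3 runs between two limits, so none of them gives a readable size or direction, because the limit of < 10000 nM in this assay, at which 2 of the 3 values shown sit, hides where compound 2 and compound 3 actually sit. Compound 1 alone provides a number at this position. With nothing readable among the steps, no direction beyond the scatter is expected for compound 4, and its value is estimated with a wide range. Compound 4 is expected to give 5000 nM, between 1500 nM and 15000 nM, which is an expected step that the limit leaves unreadable from compound 2 to compound 4.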

Compound 4, inhibition constant: < 10000 nM
Compound 4 ended at the assay's limit; the forecaster's own chance of this, stated with the estimate: 50%; the middle value is on the limit's open side.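

None of the steps from compound 1, compound 2 or compound 3 to compound 4 can be read, because all of them run into one limit: the limit of < 10000 nM in this assay, at which 3 of the 4 values shown sit. The compounds shown leave open where compound 2, compound 3 and compound 4 actually sit, and whether any of them differs from compound 1.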